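Hydroxycarbamoyl chain ends in the cell-growth series

The source may report more compounds than this note shows. Statements on the series, on what has been measured and on what is new or still open speak of the compounds shown alone.

Working notes on one step within the series. The activity read-out is a functional assay on A549 cells (Homo sapiens) for inhibition, read by MTT assay, with a stated time of 72 h; a higher number here means a weaker inhibitor, a lower number a stronger inhibitor. Within the data shown here, compound 1, `CNC(=O)CCCCCCCn1nc(-c2ccc3oc(N)nc3c2)c2c(N)ncnc21`, gives 8360 nM in this assay and is the only compound of the three measured so far to return a number rather than a limit. Compound 2, `Nc1nc2cc(-c3nn(CCCCCC(=O)NO)c4ncnc(N)c34)ccc2o1`, returns only a limit of the assay, > 100000 nM, in this assay. Compound 3, `Nc1nc2cc(-c3nn(CCCCC(=O)NO)c4ncnc(N)c34)ccc2o1`, likewise returns only a limit, > 100000 nM, in this assay. Both sit at the limit of > 100000 nM in this assay, at which 2 of the 3 values shown sit. The measured steps are accordingly an at least 11-fold higher number from compound 1 to compound 2 (1.07 log units; beyond the scatter) and an at least 11-fold higher number from compound 1 to compound 3 (1.07 log units; beyond the scatter); the comparison of compound 2 with compound 3 is a step that the two limits leave unreadable from compound 2 to compound 3.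

Compound 4, `Nc1nc2cc(-c3nn(CCCCCCC(=O)NO)c4ncnc(N)c34)ccc2o1`, is not yet measured. It differs from compound 1 by hydroxycarbamoyl in place of (methylcarbamoyl)methyl on a saturated chain carbon, six bonds along the chain from an aromatic nitrogen. The two measured steps that bear on this change, from compound 1 to compound 2 and from compound 1 to compound 3, both carry the same exchange of the chain end and both ran at least to the limit in this assay. The same direction and a comparably large loss are therefore expected for compound 4, with a real chance that only a limit is reported; the estimated step is an 8.4-fold higher number from compound 1 to compound 4 (0.92 log units; beyond the scatter). Compound 4 is expected to give about 70000 nM in this assay, within a range of 15000 nM to 250000 nM.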

Compound 4, half-maximal inhibitory concentration: 33000 nM
Compound 4: middle estimate off by 2.1-fold (0.33 log units), on the high side, within the range that was stated.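

Among these compounds, compound 4 gives the first number for a chain ending in hydroxycarbamoyl in this assay, and it sizes the exchange at this position: a 3.9-fold higher number from compound 1 to compound 4 (0.60 log units; beyond the scatter). Chain length also matters among the hydroxycarbamoyl compounds. The two shorter chains give way to a readable value, with an at least 3.0-fold lower number from compound 3 to compound 4 (0.48 log units; beyond the scatter) and an at least 3.0-fold lower number from compound 2 to compound 4 (0.48 log units; beyond the scatter). The hydroxycarbamoyl end alone does not carry the whole loss seen earlier. Those two steps are bounds only, since compound 2 and compound 3 each return a limit of the assay rather than a number: the limit of > 100000 nM in this assay, at which 2 of the 4 values shown sit.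

The step between compound 2 and compound 3 cannot be read, and the steepness of the change with chain length stays undefined while both shorter chains rest on limits. Open too, as far as these compounds go, is whether a longer chain ending in hydroxycarbamoyl would close the remaining gap to compound 1, and how a carboxylic acid or a primary amide at the same chain end would compare with hydroxycarbamoyl at the chain length of compound 4.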